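A few compounds are considered here, and "the series" means these few. Any claim that something is new, unique, unknown or untested is made for them only; others in the source may bear on it.

Measured so far in a functional assay on the whole organism (artery, strain albino) with Rattus norvegicus as the target, with a stated time of 30 min, at a dose of 10 mg/kg by the oral route; on this read-out lower numbers stand for less inhibition and higher numbers for more inhibition at the one dose given (going by the name of the read-out):
compound 1, `CC1=C(C(=O)Nc2ccc([N+](=O)[O-])cc2)C(c2ccc(Br)cc2)N=C(SCc2ccccc2Cl)N1`: 3.6%
compound 2, `CC1=C(C(=O)Nc2ccc([N+](=O)[O-])cc2)C(c2ccc(Br)cc2)N=C(SCc2cccc(Cl)c2)N1`: 2.6%

Compound 2 holds the lowest of the two numbers in this assay; its nearest neighbour is compound 1, and the step of a number 1 percentage points lower from compound 1 to compound 2 (within the scatter) lies within the scatter, so the two are not distinguished by this read-out.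

Compound 3 is `CC1=C(C(=O)Nc2ccc([N+](=O)[O-])cc2)C(c2ccc(Br)cc2)N=C(SCc2ccc(Cl)cc2)N1`. It differs from compound 2 by 4-chlorophenyl in place of 3-chlorophenyl on a saturated chain carbon bound to a sulfur. Within the data shown here, the one measured step that bears on this change is a number 1 percentage points lower from compound 1 to compound 2 (within the scatter), which also exchanged one chlorophenyl for another on the saturated chain carbon bound to a sulfur and stayed within the scatter. With both measured values near the bottom of the scale and no step beyond the scatter on record, no change beyond the scatter is expected for compound 3 in this assay; the expected step is a number 0.4 percentage points higher from compound 2 to compound 3 (within the scatter).

Compound 3 is therefore estimated at 3% in this assay, with a range from 0% to 12%.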

Compound 3, a percentage reported as inhibition, in the whole organism at one dose (the size of the read-out at that dose, not a potency): 6.2%
For compound 3 the middle estimate is 3.2 percentage points below the measured one, and the stated range covers the measured number.
By their numbers in this assay, from the lowest: compounds 2, 1 and 3 (each within the scatter of the next).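

With the 4-chlorophenyl group of compound 3 on the saturated chain carbon bound to a sulfur, all three chlorophenyl isomers can now be compared in this assay. The change reads a number 3.6 percentage points higher from compound 2 to compound 3 (within the scatter) and a number 2.6 percentage points higher from compound 1 to compound 3 (within the scatter), so no placing of the chlorine among these three is separated from the others by this read-out at the one dose given. No measurement on record here offers an explanation for these steps.

On these data alone, whether a benzyl group without chlorine, or one carrying methoxy or a carboxylic acid, would move the read-out beyond the scatter remains open. Also open, as far as these compounds go, is what an amine in place of the (4-chlorobenzyl)sulfanyl group, or a longer chain between the sulfur and the ring, would do.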